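Series notes: swapping the 2-chloroethyl chain for cyclopentyl

The compounds below may be only part of what the source reports. "The series", "measured", "known", "first", "only" and "open" are said of these compounds alone.

Compound 3 `O=C(O)/C=C/c1ccc(/C(=C(/CCCl)c2ccccc2)c2ccc3[nH]ncc3c2)cc1` gives 9 nM in a functional assay on MCF7 cells (Homo sapiens) for cytotoxicity, read by CellTiter-Glo, with a stated time of 5 days (a higher number here means a weaker inhibitor, a lower number a stronger inhibitor), the lowest of the three numbers, though within the scatter of compound 1. Compound 1 `CCC/C(=C(/c1ccc(/C=C/C(=O)O)cc1)c1ccc2[nH]ncc2c1)c1ccccc1` gives 11 nM, and the step of a 1.2-fold lower number from compound 1 to compound 3 (0.09 log units; within the scatter) separates neither from the other. Compound 2 `COCC/C(=C(/c1ccc(/C=C/C(=O)O)cc1)c1ccc2[nH]ncc2c1)c1ccccc1` gives 63 nM; the steps of a 5.7-fold higher number from compound 1 to compound 2 (0.76 log units; beyond the scatter) and a 7.0-fold lower number from compound 2 to compound 3 (0.85 log units; beyond the scatter) are the only ones beyond the scatter. Compound 4 `O=C(O)/C=C/c1ccc(/C(=C(\c2ccccc2)C2CCCC2)c2ccc3[nH]ncc3c2)cc1` differs from compound 3 by cyclopentyl in place of 2-chloroethyl on a double-bonded chain carbon bound to an aromatic carbon and a double-bonded chain carbon. All measured steps vary the group on the saturated chain carbon two bonds along; none replaces the whole chain with a ring, so they bear only loosely, showing modest shifts at most. Compound 4 is therefore estimated at 25 nM, range 8 nM to 80 nM. The expected step of a 2.8-fold higher number from compound 3 to compound 4 (0.44 log units; beyond the scatter) is small.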

Compound 4, half-maximal inhibitory concentration: 10 nM
Compound 4: middle estimate off by 2.5-fold (0.40 log units), on the high side, within the range that was stated.
By their numbers in this assay, from the lowest: compounds 3, 4 and 1 (each within the scatter of the next); then compound 2.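

At this position, on a double-bonded chain carbon bound to an aromatic carbon and a double-bonded chain carbon, a ring now stands in for the open chains in this assay: cyclopentyl in place of 2-chloroethyl gives a 1.1-fold higher number from compound 3 to compound 4 (0.05 log units; within the scatter), and cyclopentyl in place of propyl gives a 1.1-fold lower number from compound 1 to compound 4 (0.04 log units; within the scatter), so this assay does not separate the ring from either chain. Cyclopentyl in place of 2-methoxyethyl gives a 6.3-fold lower number from compound 2 to compound 4 (0.80 log units; beyond the scatter), the only new step beyond the scatter. No evidence on the cause of these results is available.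

Going by these compounds, whether cyclohexyl, or a cyclopentyl ring carrying an amine, would keep the number close to that of compound 4 remains open.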